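The source may hold more compounds than are shown below. What is called first, only, known or untested is meant among the compounds shown, and "the series" means these compounds.

Measured in a functional assay on OVCAR-8 cells (Homo sapiens) for antiproliferative activity; a higher number here means a weaker inhibitor, a lower number a stronger inhibitor:
- compound 1 `Cn1ncc(Cl)c1-c1cc(C(=O)N[C@@H]2CN[C@H](CC(=O)NC3CC3)C[C@H]2c2ccc(Cl)c(Cl)c2)oc1Cl`: 580 nM
- compound 2 `Cn1ncc(Cl)c1-c1cc(C(=O)N[C@@H]2CN[C@H](CCO)C[C@H]2c2ccc(Cl)c(Cl)c2)oc1Cl`: 610 nM
- compound 3 `Cn1ncc(Cl)c1-c1cc(C(=O)N[C@@H]2CN[C@H](CCN3CCCC3)C[C@H]2c2ccc(Cl)c(Cl)c2)oc1Cl`: 1840 nM

Of these three, compound 3 has the highest number and is the weakest inhibitor, with both gaps beyond the scatter: a 3.2-fold higher number from compound 1 to compound 3 (0.50 log units; beyond the scatter) and a 3.0-fold higher number from compound 2 to compound 3 (0.48 log units; beyond the scatter).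

The next compound to be tested is compound 4 `Cn1ncc(Cl)c1-c1cc(C(=O)N[C@@H]2CN[C@H](CC(=O)NC3CCC3)C[C@H]2c2ccc(Cl)c(Cl)c2)oc1Cl`. It puts cyclobutylcarbamoyl in place of (pyrrolidin-1-yl)methyl on a saturated chain carbon bound to a saturated ring carbon.

The most relevant evidence is a 3.2-fold higher number from compound 1 to compound 3 (0.50 log units; beyond the scatter), a modest step in which cyclopropylcarbamoyl gave way to (pyrrolidin-1-yl)methyl at that same place. Compound 4 runs in the opposite direction, but with a cyclobutyl amide, and no such amide has been measured yet. The other two steps fit this picture: a 3.0-fold higher number from compound 2 to compound 3 (0.48 log units; beyond the scatter) is also modest, while a 1.1-fold higher number from compound 1 to compound 2 (0.02 log units; within the scatter) stays within the scatter.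

A modest move to a lower number in this assay is therefore expected. The estimated change is a 3.0-fold lower number from compound 3 to compound 4 (0.47 log units; beyond the scatter). For compound 4 the expected value is 620 nM, with an estimated range of 280 nM to 1350 nM.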

Compound 4, half-maximal inhibitory concentration: 610 nM
The estimate for compound 4 lay 1.0-fold (0.01 log units) above the measured number; measured number inside the range.
By their numbers in this assay, from the lowest: compounds 1, 2 and 4 (each within the scatter of the next); then compound 3.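

In this assay, the amide side chain keeps its level when its ring changes, with cyclobutyl in place of cyclopropyl on an amide-type nitrogen giving a 1.1-fold higher number from compound 1 to compound 4 (0.02 log units; within the scatter). Within the data shown here, exchanging the amide for hydroxymethyl likewise gives no change at the digits printed from compound 2 to compound 4 (within the scatter), whereas the comparison with the basic-looking name aside, (pyrrolidin-1-yl)methyl remains the one group that stands apart, with cyclobutylcarbamoyl in its place giving a 3.0-fold lower number from compound 3 to compound 4 (0.48 log units; beyond the scatter). No measurement here explains why these groups group as they do.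

Going by these compounds, whether a cyclohexyl amide, with a still larger ring on the amide nitrogen, would stay level with compound 1 and compound 4 remains open. So does whether a carboxylic acid or a dimethylamino group in this place would match compound 2 or compound 3.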